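The source may hold more compounds than are shown below. What is called first, only, known or untested is meant among the compounds shown, and "the series" means these compounds.

Working notes on the chromone series and its amide pairs.

Among the measured compounds shown here, compound 3 `CCCC(=O)Nc1cccc(NC(=O)COc2ccc3c(=O)ccoc3c2)c1` is the one compound with a number in an assay on isolated protein for inhibition of Rho-associated protein kinase 2 (Homo sapiens), read by scintillation counting, radiometric assay and 33P incorporation, with a stated time of 40 min, in the presence of a further agent that is not named here; a lower number here means a stronger inhibitor, a higher number a weaker inhibitor: compound 3 gives 176 nM. Compound 1 `COc1ccc(OCC(=O)Nc2cccc(NC(=O)c3ccc(N(C)C)cc3)c2)cc1OC` reaches only a limit, where compound 1 gives > 10000 nM. Compound 2 `CN(C)c1ccc(C(=O)Nc2cccc(NC(=O)COc3ccc4occc(=O)c4c3)c2)cc1` likewise stops at a limit, and compound 2 gives > 10000 nM. For the measured compounds named here, the one measured step that changes a single place, a step that the two limits leave unreadable from compound 1 to compound 2, cannot be read, since both ends sit at the limit of > 10000 nM in this assay, at which 2 of the 3 values shown sit.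

Compound 4 `O=C(COc1ccc2c(=O)ccoc2c1)Nc1cccc(NC(=O)c2ccc([N+](=O)[O-])cc2)c1` differs from compound 3 in the acyl part:
4-nitrophenyl in place of propyl on a carbonyl carbon
Going by the values given here, no measured step bears directly on this change. Among the compounds with values here, compound 2 carries an aryl carbonyl on the same amide nitrogen and sits at the limit, while compound 3 carries propylcarbonyl and is the only compound with a number. On that evidence alone, compound 4 is expected to be weaker than compound 3, with an expected step of a 17-fold higher number from compound 3 to compound 4 (1.23 log units; beyond the scatter) in this assay. The estimated value for compound 4 is 3000 nM, with a range from 500 nM to 20000 nM, and a fair chance that only a limit is returned.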

Compound 4, half-maximal inhibitory concentration: 15 nM
Compound 4: middle estimate off by 200-fold (2.30 log units), on the high side, outside the stated range (below it).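

In this assay, setting 4-nitrophenyl in place of propyl on the carbonyl carbon gives a 12-fold lower number from compound 3 to compound 4 (1.07 log units; beyond the scatter). On this core, then, the place on the carbonyl carbon is not confined to a short alkyl chain: it accepts an aromatic ring that carries a nitro group, and the number improves rather than reaching the limit of the assay. Nothing shown gives a measured reason for the size of this step.

The compounds shown do not separate the share of the aromatic ring from that of the nitro group, and a plain phenyl, or a phenyl with an amine or a carboxylic acid in place of the nitro group, would address this on the same core. Also open, as far as these compounds go, is how a longer alkyl chain than propyl would read at this place.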